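Replacing cyanomethyl on the aromatic nitrogen: compound 4

The compounds below may be only part of what the source reports. "The series", "measured", "known", "first", "only" and "open" are said of these compounds alone.

In a functional assay on MCF7 cells (Homo sapiens) for cytotoxicity, read by sulforhodamine B assay, with a stated time of 48 h (on this read-out higher numbers stand for weaker inhibition and lower numbers for stronger inhibition), compound 1 `N#CCn1c(-c2ccco2)nc2ccccc21` gives 88100 nM. Compound 2 `S=c1[nH]nc(Cn2c(-c3ccco3)nc3ccccc32)s1` gives 52600 nM and compound 3 `N#C/C(=C1/SCC(=O)N1c1ccccc1)n1c(-c2ccco2)nc2ccccc21` gives 55900 nM. Compound 1 therefore lies within the scatter of both.

Compound 4 `SC1=NNCC(n2c(-c3ccco3)nc3ccccc32)=N1` differs from compound 1 on an aromatic nitrogen: a group of 7 heavy atoms (3 carbon, 3 nitrogen, 1 sulfur; one six-membered non-aromatic ring with 3 hetero atoms) in place of a group of 3 heavy atoms (2 carbon, 1 nitrogen; no ring), on an aromatic nitrogen.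

Among the compounds with values here, the only measured step that bears on this is a 1.7-fold lower number from compound 1 to compound 2 (0.22 log units; within the scatter). It also brings in a larger ring-bearing group, but on a saturated chain carbon bound to an aromatic nitrogen, so it is an imperfect guide. That step stays within the scatter, and no step beyond the scatter is expected in this assay. The estimated step is a 1.6-fold lower number from compound 1 to compound 4 (0.20 log units; within the scatter). Compound 4 is expected at 55000 nM, with an estimated range of 25000 nM to 120000 nM.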

Compound 4, half-maximal inhibitory concentration: 60500 nM
Compound 4: the middle estimate sits 1.1-fold (0.04 log units) below what was measured, and the stated range covers the measured number.
By their numbers in this assay, from the lowest: compounds 2, 3, 4 and 1 (each within the scatter of the next).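

On the aromatic nitrogen, a six-membered non-aromatic ring with 3 hetero atoms in place of cyanomethyl gives a 1.5-fold lower number from compound 1 to compound 4 (0.16 log units; within the scatter) in this assay, so a ring group placed directly on this nitrogen produces no step beyond the scatter. The six-membered ring and the group of compound 2 also read alike, with a 1.2-fold higher number from compound 2 to compound 4 (0.06 log units; within the scatter). Nothing available accounts for this result.

No group shown here moves the number beyond the scatter at this position. On these data alone, whether an amine, a carboxylic acid or a longer alkyl chain on this nitrogen would do so stays open.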